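The source may hold more compounds than are shown below. What is called first, only, known or untested is meant among the compounds shown, and "the series" means these compounds.

Compound 2 `C/C(=N\Nc1nc(-c2ccc(Cl)cc2)cs1)c1sc(-c2ccccc2)nc1C` was tested in a toxicity assay on HCT-116 cells (Homo sapiens) for cytotoxicity, read by MTT assay (a higher number here means a weaker inhibitor of growth, a lower number a stronger inhibitor of growth), and its reading is a limit of the assay rather than a number: compound 2 gives > 100 ug/mL. Compound 1 `C/C(=N\Nc1nc(-c2ccc(C)cc2)cs1)c1sc(C)nc1C`, which shares the same core, also reaches only a limit, giving > 100 ug/mL. Both readings thus sit at the same boundary (the limit of > 100 ug/mL in this assay, at which 2 of the 2 values shown sit). Compound 3 `C/C(=N\Nc1nc(-c2ccc(C)cc2)cs1)c1sc(-c2ccccc2)nc1C` has not yet been measured; it differs from compound 2 by methyl in place of chloro on an aromatic carbon. Since both measured compounds stop at the limit (the limit of > 100 ug/mL in this assay, at which 2 of the 2 values shown sit), the step that the limit leaves unreadable from compound 2 to compound 3 is expected to be none beyond the scatter. Compound 3 is therefore estimated at 150 ug/mL, between 60 ug/mL and 400 ug/mL.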

Compound 3, concentration for 50% growth inhibition: > 100 ug/mL
Compound 3 gave a limit, no number; the forecaster's own chance of this, stated with the estimate: 85%; the middle value is on the limit's open side.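

No step can be read among compound 1, compound 2 and compound 3, as each gives only a limit: the limit of > 100 ug/mL in this assay, at which 3 of the 3 values shown sit. The compounds shown leave open whether either change to the shared core alters growth inhibition in this assay.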